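Trifluoromethoxy to methoxy: expected effect on plasma protein binding

The compounds below may be only part of what the source reports. "The series", "measured", "known", "first", "only" and "open" are said of these compounds alone.

Of the two measured compounds, compound 1 `CNc1nccc(N2CC[C@H](NC(=O)Nc3ccc(OC(F)(F)F)cc3)C2)n1` shows the higher plasma protein binding in an ADME assay on a cell-free system (plasma, Rattus norvegicus) for protein binding: compound 1 gives 98.1%, whereas compound 2 `CCN1CCN(Cc2ccc(NC(=O)N[C@H]3CCN(c4ccnc(NC)n4)C3)cc2C(F)(F)F)CC1` gives 84.2%, a gap in unbound fraction that lies beyond the scatter. Compound 3 `CNc1nccc(N2CC[C@H](NC(=O)Nc3ccc(OC)cc3)C2)n1` differs from compound 1 in a single place: methyl in place of trifluoromethyl on an oxygen on an aromatic ring. Going by the values given here, no measured pair carries this same change, so its effect is not known from the data. A modest step toward lower binding is expected, a 3.2-fold higher unbound fraction from compound 1 to compound 3 (0.50 log units; beyond the scatter). For compound 3 the estimated value is 94%, with a range from 88% to 97.5%.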

Compound 3, plasma protein binding: 86.3%
Compound 3: middle estimate off by 2.3-fold (0.36 log units) (unbound fraction), on the low side; the whole stated range lies above it.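

In this assay, going by these compounds alone, methyl in place of trifluoromethyl on an oxygen on an aromatic ring gives a 7.2-fold higher unbound fraction from compound 1 to compound 3 (0.86 log units; beyond the scatter), the only single-place step so far. This one position can therefore move binding beyond the scatter with the rest of compound 1 unchanged. No measured evidence on hand accounts for the size of this step.

Still open, on these data alone, is how binding responds to an amine or a carboxylic acid in place of trifluoromethoxy, or to a longer chain on the oxygen. As far as these compounds go, whether the step carries over to other compounds also remains open.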